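The compounds below may be only part of what the source reports. "The series", "measured", "known", "first", "only" and "open" are said of these compounds alone.

Compound 1 `O=C(/C=C(O)/C=C/c1ccccc1)c1ccccc1O` gives 1160 nM in an in vitro assay on cells for inhibition of Amine oxidase [flavin-containing] B (Homo sapiens), read by Amplex Red, with a stated time of 15 min; on this read-out higher numbers stand for weaker inhibition and lower numbers for stronger inhibition.
Compound 2 `O=C(/C=C/C=C/c1ccc([N+](=O)[O-])cc1)c1cc(Cl)ccc1O` gives 1080 nM in this assay.
Compound 3 `O=C(/C=C/C=C/c1ccc([N+](=O)[O-])cc1)c1ccccc1O` gives 160 nM in this assay.

Among these three, compound 3 stands lowest: its nearest neighbour is compound 2, and the one step that is documented, a 6.8-fold lower number from compound 2 to compound 3 (0.83 log units; beyond the scatter), lies beyond the scatter. Within the data shown here, compound 1 sits furthest from compound 3, but no single-point step joins those two, since they differ in more than one place, so their values only show that compound 1 gives a clearly higher number than compound 3.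

Compound 4 `O=C(/C=C(O)/C=C/c1ccc([N+](=O)[O-])cc1)c1ccccc1O` is the next compound to be measured in this assay. It departs from compound 3 by hydroxy in place of hydrogen on a double-bonded chain carbon bound to two double-bonded chain carbons. Among the measured compounds shown here, no measured step bears directly on this change; the only documented step, from compound 2 to compound 3, concerns a chloro group on an aromatic carbon, not a hydroxy on the chain. Compound 1, which carries the same hydroxy on its chain, gives a higher number than compound 3, but the nitro group differs as well, so this is only a hint.

For the measured compounds named here, with no step to lean on, the expectation for compound 4 is a modest drift upward, a 2.5-fold higher number from compound 3 to compound 4 (0.40 log units; beyond the scatter), and the estimated value for compound 4 is 400 nM, with a range from 140 nM to 1200 nM.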

Compound 4, half-maximal inhibitory concentration: 2670 nM
Compound 4: the middle estimate sits 6.7-fold (0.82 log units) below what was measured; measured number outside the range, above it.
By their numbers in this assay, from the lowest: compound 3; then compounds 2 and 1 (each within the scatter of the next); then compound 4.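

In this assay, the change of hydrogen to hydroxy on a double-bonded chain carbon bound to two double-bonded chain carbons now has a direct reading, and it is a large one: a 17-fold higher number from compound 3 to compound 4 (1.22 log units; beyond the scatter). Among these compounds, the earlier step concerned only chloro on an aromatic carbon, so this is the first sign that this chain position is highly sensitive to substitution, at least with the nitro group present. The second reading, a 2.3-fold higher number from compound 1 to compound 4 (0.36 log units; beyond the scatter), shows that nitro in place of hydrogen on an aromatic carbon does not lower the number when the chain carries the hydroxy, and compound 3, without that hydroxy, stays lowest of the four; no measured evidence accounts for this result. Among the compounds shown, the effect of the nitro group on a chain without the hydroxy stays open, so it cannot be said how far the two changes depend on each other. Also open, going by these compounds, is whether a methoxy group, an amine or a fluorine atom at the same chain carbon would raise the number as hydroxy does.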